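This account rests on a few compounds, and the source may have more. Where it says the series, first, only, none or still open, it means among the compounds named here.

Measured in a functional assay on MKN-45 cells (Homo sapiens) for inhibition, read by CCK-8 assay, with a stated time of 24 h; a higher number here means a weaker inhibitor, a lower number a stronger inhibitor:
- Compound 1 `Cc1cccc(-n2cc(-c3ccc(/C=C4\C(=O)Nc5ccccc54)cc3)nn2)c1`: 4690 nM
- Compound 2 `O=C1Nc2ccccc2/C1=C/c1ccc(-c2cn(-c3ccc(F)cc3)nn2)cc1`: 16700 nM
- Compound 3 `O=C1Nc2ccccc2/C1=C/c1ccc(-c2cn(-c3ccc(Cl)cc3)nn2)cc1`: 16200 nM

Compound 3, at 16200 nM, stands level with compound 2: a 1.0-fold lower number from compound 2 to compound 3 (0.01 log units; within the scatter), a step within the scatter. Compound 1 lies clearly apart, with a 3.5-fold higher number from compound 1 to compound 3 (0.54 log units; beyond the scatter).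

Compound 4 `N#Cc1ccccc1-n1cc(-c2ccc(/C=C3\C(=O)Nc4ccccc43)cc2)nn1` keeps the shared core and carries 2-cyanophenyl in place of 4-chlorophenyl on an aromatic nitrogen. Going by the values given here, three measured steps bear on this exchange. Two replace the group at this same place and are modest: a 3.6-fold higher number from compound 1 to compound 2 (0.55 log units; beyond the scatter) and a 3.5-fold higher number from compound 1 to compound 3 (0.54 log units; beyond the scatter). The third, a 1.0-fold lower number from compound 2 to compound 3 (0.01 log units; within the scatter), shows no change between the two halogen-bearing compounds.

Among the compounds with values here, no measured compound carries a nitrile, so the data do not fix the direction. A step of no more than modest size is therefore expected in this assay. Within the data shown here, it leans slightly towards a lower number, as compound 1, the only measured compound without a halogen, gives 4690 nM. The expected step is a 1.6-fold lower number from compound 3 to compound 4 (0.21 log units; within the scatter). For compound 4 the estimate is 10000 nM, within an expected range from 3500 nM to 28000 nM.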

Compound 4, half-maximal inhibitory concentration: 14600 nM
Compound 4: the middle estimate sits 1.5-fold (0.16 log units) below what was measured; low and high end bracket the measured number.
By their numbers in this assay, from the lowest: compound 1; then compounds 4, 3 and 2 (each within the scatter of the next).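

In this assay, going by these compounds alone, 2-cyanophenyl on an aromatic nitrogen, the first group at this place to carry a nitrile and a hydrogen-bond acceptor, stands level with both halogen-bearing groups, with a 1.1-fold lower number from compound 3 to compound 4 (0.05 log units; within the scatter) and a 1.1-fold lower number from compound 2 to compound 4 (0.06 log units; within the scatter). This leaves 3-methylphenyl alone at the low end of the set: with a 3.1-fold higher number from compound 1 to compound 4 (0.49 log units; beyond the scatter), the gap to compound 1 now holds against three different groups, and compound 1 remains the strongest inhibitor of the four. No measured evidence here explains why compounds 2, 3 and 4 fall together or why compound 1 stands apart.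

The compounds shown leave open whether the lower number of compound 1 belongs to the methyl group itself or to the place it occupies on the phenyl ring, a question that 4-methylphenyl, 2-methylphenyl or plain phenyl would address. They also leave open how this assay would respond to a phenyl ring bearing an amine or a carboxylic acid, or to a longer alkyl chain in place of the phenyl ring on this nitrogen.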